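This account rests on a few compounds, and the source may have more. Where it says the series, first, only, none or still open, it means among the compounds named here.

Compound 1 `C#CCn1c(=O)c(C=O)cc2cc(F)ccc21` — > 100000 nM, a limit of the assay
Compound 2 `C#CCn1c(=O)c(C=O)cc2cc(C)ccc21` — > 100000 nM, a limit of the assay
Compound 3 `C#CCn1c(=O)c(/C=C/C(=O)/C=C(O)/C=C/c2ccc(O)c(OC)c2)cc2cc(C)ccc21` — 36200 nM

In a functional assay on MCF7 cells (Homo sapiens) for cytotoxicity, read by MTT assay, with a stated time of 24 h (a higher number here means a weaker inhibitor, a lower number a stronger inhibitor), compound 1 gives > 100000 nM, which is a limit rather than a number. Compound 2 gives > 100000 nM, again a limit. Among the compounds with values here, compound 3 gives 36200 nM, the only number among the three. Compound 1 differs from compound 2 by fluoro in place of methyl on an aromatic carbon; the step that the two limits leave unreadable from compound 2 to compound 1 cannot be read because of the limit of > 100000 nM in this assay, at which 2 of the 3 values shown sit. How the core of compound 3 differs from that of compound 2 is not broken down here. Compound 4 `C#CCn1c(=O)c(/C=C/C(=O)/C=C(O)/C=C/c2ccc(O)c(OC)c2)cc2cc(F)ccc21` is not yet measured and differs from compound 3 by fluoro in place of methyl on an aromatic carbon, the same change at the same place. Since the earlier step is unreadable, the expectation rests on compound 3 at 36200 nM alone, and the step of a 1.1-fold higher number from compound 3 to compound 4 (0.04 log units; within the scatter) is expected to be small. Compound 4 is therefore estimated at 40000 nM, between 15000 nM and 120000 nM.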

Compound 4, half-maximal inhibitory concentration: 25000 nM
Compound 4: middle estimate off by 1.6-fold (0.20 log units), on the high side; low and high end bracket the measured number.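

On the core of compound 3 in this assay, fluoro in place of methyl on an aromatic carbon gives a 1.4-fold lower number from compound 3 to compound 4 (0.16 log units; within the scatter), so on this core the change does not move the result beyond the usual scatter. The same change on the other core, from compound 2 to compound 1, cannot be read because both compounds sit at a limit: the limit of > 100000 nM in this assay, at which 2 of the 4 values shown sit. The series therefore offers one readable pair, which does not show whether the change behaves alike on both cores.

The compounds shown leave open whether a different group on that aromatic carbon, such as an amine, a carboxylic acid or a longer alkyl chain, would give a step beyond the scatter.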